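Replacing a propylamino chain with a dimethylpiperidine ring

A few compounds are considered here, and "the series" means these few. Any claim that something is new, unique, unknown or untested is made for them only; others in the source may bear on it.

Measured compounds:
compound 1 `CC1=NN(C(=O)c2ccc(C)cc2)C(c2ccccc2O)C1` — 40600 nM
compound 2 `CC1=NN(C(=O)COc2ccc(Cl)cc2)C(c2ccccc2O)C1` — 38800 nM
compound 3 `CCCNCC(=O)N1N=C(c2cc3ccccc3oc2=O)CC1c1ccccc1` — 7270 nM

In a functional assay on PC-3 cells (Homo sapiens) for cytotoxicity, read by MTT assay, with a stated time of 48 h (a lower number here means a stronger inhibitor, a higher number a weaker inhibitor), compound 3 gives 7270 nM, the lowest of the three numbers. Compound 2 gives 38800 nM and compound 1 gives 40600 nM; both gaps to compound 3 lie beyond the usual scatter, so compound 3 is the strongest inhibitor among the measured set. Compound 1 and compound 2 share a core that differs from that of compound 3, and no single-point comparison links them to it.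

Compound 4 `CC1CC(C)CN(CC(=O)N2N=C(c3cc4ccccc4oc3=O)CC2c2ccccc2)C1` has not yet been measured. It differs from compound 3 in one place: 3,5-dimethylpiperidin-1-yl in place of propylamino on a saturated chain carbon bound to a carbonyl carbon. Going by the values given here, no measured pair shows a step of this kind. The expected direction therefore rests on compound 3 alone, which gives 7270 nM. The change from compound 3 to compound 4 is expected to stay close to the scatter, a 1.1-fold lower number from compound 3 to compound 4 (0.05 log units; within the scatter). Compound 4 is therefore estimated at 6500 nM in this assay, with a range from 2200 nM to 20000 nM.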

Compound 4, half-maximal inhibitory concentration: "not active" (no number reported)
Compound 4 has no reported number here, so the estimate cannot be set against anything.
By their numbers in this assay, from the lowest: compound 3; then compounds 2 and 1 (each within the scatter of the next).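

Going by these compounds alone, compound 4 is reported as not active, without a number, so no step from compound 3 to compound 4 can be read. Nothing shown here bears on this result. The compounds shown leave open how far 3,5-dimethylpiperidin-1-yl in place of propylamino weakens the number, if it does.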